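Hydrazone aryl variation on a shared core: cytotoxicity notes

The source may report more compounds than this note shows. Statements on the series, on what has been measured and on what is new or still open speak of the compounds shown alone.

compound 1, `CN(C)CCn1cnnc1-c1cc(Oc2ccc(NC(=O)N/N=C/c3c[nH]c4ccccc34)cc2F)ccn1`: 3620 nM
compound 2, `CN(C)CCn1cnnc1-c1cc(Oc2ccc(NC(=O)N/N=C/c3ccc(O)c(Br)c3)cc2F)ccn1`: 5560 nM
compound 3, `CN(C)CCn1cnnc1-c1cc(Oc2ccc(NC(=O)N/N=C/c3ccccc3O[N+](=O)[O-])cc2F)ccn1`: 6860 nM

All three compounds share one core and differ only in the aryl group on the carbon with a double bond to nitrogen. In an ADME assay on WI-38 cells (Homo sapiens) for cytotoxicity, read by MTT assay, with a stated time of 72 h (on this read-out lower numbers stand for stronger inhibition and higher numbers for weaker inhibition), compound 1 gives 3620 nM, compound 2 gives 5560 nM and compound 3 gives 6860 nM. The steps among them are a 1.5-fold higher number from compound 1 to compound 2 (0.19 log units; within the scatter), a 1.9-fold higher number from compound 1 to compound 3 (0.28 log units; within the scatter) and a 1.2-fold higher number from compound 2 to compound 3 (0.09 log units; within the scatter). Compound 1 therefore sits at the low end of the three numbers without being set apart from either neighbour, since all steps from it fall within the scatter.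

Among the compounds with values here, compound 4, `CN(C)CCn1cnnc1-c1cc(Oc2ccc(NC(=O)N/N=C/c3c(O)ccc4ccccc34)cc2F)ccn1`, has not yet been read in this assay. The change from compound 1 is 2-hydroxynaphthalen-1-yl in place of 1H-indol-3-yl on a carbon with a double bond to nitrogen. The two measured steps that bear on it are those from compound 1, a 1.5-fold higher number from compound 1 to compound 2 (0.19 log units; within the scatter) and a 1.9-fold higher number from compound 1 to compound 3 (0.28 log units; within the scatter), which exchange the same group and stay within the scatter in both cases. No step beyond the scatter is expected in this assay from this change either. For compound 4 the expected value in this assay is 4500 nM. The estimated range for compound 4 runs from 2000 nM to 10000 nM. The step this estimate means is a 1.2-fold higher number from compound 1 to compound 4 (0.09 log units; within the scatter), expected to stay within the scatter.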

Compound 4, half-maximal inhibitory concentration: 3250 nM
Estimate against measurement, compound 4: 1.4-fold (0.14 log units) above, within the range that was stated.
By their numbers in this assay, from the lowest: compounds 4, 1, 2 and 3 (each within the scatter of the next, the first and the last beyond it).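

In this assay, the series accepts an aryl group made of 2 six-membered aromatic rings of carbon only on the carbon with a double bond to nitrogen: 2-hydroxynaphthalen-1-yl in place of 1H-indol-3-yl leaves the number within the scatter (a 1.1-fold lower number from compound 1 to compound 4 (0.05 log units; within the scatter)), so the ring nitrogen of the indole is not needed to hold this level of cytotoxicity. Within the data shown here, the same group also gives the first step in this set that lies beyond the scatter, though only a modest one, when it replaces 2-(nitrooxy)phenyl (a 2.1-fold lower number from compound 3 to compound 4 (0.32 log units; beyond the scatter)), whereas its step from 3-bromo-4-hydroxyphenyl stays within the scatter (a 1.7-fold lower number from compound 2 to compound 4 (0.23 log units; within the scatter)). No measurement at hand explains any of these steps.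

The compounds shown leave open whether the hydroxyl of compound 4 matters at all, a question that plain naphthalen-1-yl on the same carbon would address in this assay. They also leave open what happens when the aryl group gives way to a non-aromatic substituent at this place, such as an amine, a carboxylic acid or a longer alkyl chain.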